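Second fluoro on the amide-side ring: toward compound 3

The source may report more compounds than this note shows. Statements on the series, on what has been measured and on what is new or still open speak of the compounds shown alone.

Measured in an in vitro functional assay on HEK293-A cells for positive allosteric modulation of metabotropic glutamate receptor 5 (Homo sapiens), read by fluorescence and calcium flux, with a stated time of 140 s; on this read-out higher numbers stand for an effect only at larger amounts of compound and lower numbers for an effect already at smaller amounts:
compound 1 `O=C(c1ccc(F)c(F)c1)N1CCCC1c1nc(-c2cccc(F)c2)no1`: 3700 nM
compound 2 `O=C(c1ccc(F)cc1)N1CCCC1c1nc(-c2cccc(F)c2)no1`: 3600 nM

For the measured compounds named here, compound 2 stands alongside compound 1 on the two numbers available, and the single measured step between them is small: a 1.0-fold lower number from compound 1 to compound 2 (0.01 log units; within the scatter). Nothing else in the series separates the two.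

Compound 3 `O=C(c1ccc(F)cc1F)N1CCCC1c1nc(-c2cccc(F)c2)no1` takes compound 2 one fluoro further: fluoro in place of hydrogen on an aromatic carbon. The new fluoro sits ortho to a large group and meta to a fluoro group; cut one bond further out, the change reads 4-fluorophenyl to 2,4-difluorophenyl.

Going by the values given here, the only step that bears on this is the one from compound 1 to compound 2, which also moved a fluoro on the same ring and stayed within the scatter. Among the compounds with values here, no measured pair shows what a fluoro at this particular place does, so the expectation rests on that single small step.

The estimated step in this assay is therefore a 1.1-fold lower number from compound 2 to compound 3 (0.05 log units; within the scatter), which is expected to stay within the scatter. For compound 3 the expected value is 3200 nM, with a range from 1300 nM to 8000 nM.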

Compound 3, half-maximal effective concentration: 10000 nM
The estimate for compound 3 lay 3.1-fold (0.49 log units) below the measured number, and the stated range ends below it.
By their numbers in this assay, from the lowest: compounds 2 and 1 (each within the scatter of the next); then compound 3.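

In this assay the ring on the amide carbonyl had so far shown no measurable response to a change of fluoro, as compound 1 and compound 2 lie within the scatter of each other. For the compounds shown here, a fluoro ortho to a large group is the first change on this ring to register, with a 2.8-fold higher number from compound 2 to compound 3 (0.44 log units; beyond the scatter) as the step, and the number moves toward larger amounts of compound, though the step is only modest. The comparison of the two difluorophenyl rings gives a 2.7-fold higher number from compound 1 to compound 3 (0.43 log units; beyond the scatter) as a step of similar size, so among these three compounds the 2,4-difluorophenyl stands apart from both the 4-fluorophenyl and the 3,4-difluorophenyl, and nothing measured here accounts for this.

Open, going by these compounds, is whether the loss belongs to fluoro itself or to any group at this place, which a chloro, a methyl or a methoxy group there would help to separate. Also open, on these data alone, is whether the step holds without the fluoro group that the new fluoro sits meta to, and whether it carries over when the 3-fluorophenyl at the far end of the shared core is replaced by another ring substituent, such as a nitrile.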